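This account rests on a few compounds, and the source may have more. Where it says the series, first, only, none or still open, it means among the compounds named here.

Compound 1 `Cn1cc(CNC(=O)c2ccncc2Nc2cc(-c3ccc4ccn(C)c4c3)c3nccnc3c2)cn1`: 75900 nM
Compound 2 `Cn1ccc2ccc(-c3cc(Nc4cnccc4C(=O)NC4CCNC(=O)C4)cc4nccnc34)cc21`: 56500 nM
Compound 3 `CN1CCC(NC(=O)c2ccncc2Nc2cc(-c3ccc4ccn(C)c4c3)c3nccnc3c2)CC1=O`: 48800 nM

In an assay on lysate for inhibition of 6-phosphofructo-2-kinase/fructose-2,6-bisphosphatase 3 (Homo sapiens), with stated times of 0.5 min and 45 min (on this read-out lower numbers stand for stronger inhibition and higher numbers for weaker inhibition), compound 3 gives 48800 nM, the lowest of the three numbers shown, yet the steps of a 1.2-fold lower number from compound 2 to compound 3 (0.06 log units; within the scatter) and a 1.6-fold lower number from compound 1 to compound 3 (0.19 log units; within the scatter) both fall within the scatter, so no order among the three compounds can be claimed. Compound 4 `Cn1ccc2ccc(-c3cc(Nc4cnccc4C(=O)NCC4COCCN4)cc4nccnc34)cc21` differs from compound 3 by (morpholin-3-yl)methyl in place of 1-methyl-2-oxopiperidin-4-yl on an amide-type nitrogen. All three measured steps, a 1.3-fold lower number from compound 1 to compound 2 (0.13 log units; within the scatter), a 1.6-fold lower number from compound 1 to compound 3 (0.19 log units; within the scatter) and a 1.2-fold lower number from compound 2 to compound 3 (0.06 log units; within the scatter), exchange groups on the same amide-type nitrogen, and each stays within the scatter. On that basis compound 4 is expected to show no step beyond the scatter, a 1.1-fold higher number from compound 3 to compound 4 (0.03 log units; within the scatter). The estimate for compound 4 is 52000 nM, with a range from 20000 nM to 140000 nM.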

Compound 4, half-maximal inhibitory concentration: 41700 nM
Beside the measured number, compound 4's estimate is 1.2-fold (0.10 log units) above it; the measured number falls inside the stated range.
By their numbers in this assay, from the lowest: compounds 4, 3, 2 and 1 (each within the scatter of the next).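

In this assay, (morpholin-3-yl)methyl on this amide-type nitrogen gives a 1.2-fold lower number from compound 3 to compound 4 (0.07 log units; within the scatter), a 1.4-fold lower number from compound 2 to compound 4 (0.13 log units; within the scatter) and a 1.8-fold lower number from compound 1 to compound 4 (0.26 log units; within the scatter). A group with two hetero atoms in its six-membered non-aromatic ring thus joins the earlier three, and no step among these four groups on this nitrogen lies beyond the scatter. No measurement shown here offers an explanation for this. On these data alone, whether a carboxylic acid, a primary amine or a longer chain on this nitrogen would produce a step beyond the scatter remains open.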